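Pyridine to thiophene on the methoxy arm

This account rests on a few compounds, and the source may have more. Where it says the series, first, only, none or still open, it means among the compounds named here.

- compound 1 `CC(C)(C)Sc1c(CC(C)(C)C(=O)O)n(Cc2ccc(Cl)cc2)c2ccc(CCc3ccc4ccccc4n3)cc12`: 4 nM
- compound 2 `CC(C)(C)Sc1c(CC(C)(C)C(=O)O)n(Cc2ccc(Cl)cc2)c2ccc(OCc3nc4ccccc4s3)cc12`: 3 nM
- compound 3 `CC(C)(C)Sc1c(CC(C)(C)C(=O)O)n(Cc2ccc(Cl)cc2)c2ccc(OCc3cccnc3)cc12`: 8 nM
- compound 4 `CC(C)(C)Sc1c(CC(C)(C)C(=O)O)n(Cc2ccc(Cl)cc2)c2ccc(OCc3cccs3)cc12`: not yet measured

All values come from a functional assay for inhibition, with Homo sapiens as the target; on this read-out lower numbers stand for stronger inhibition and higher numbers for weaker inhibition. Compound 3 stands at the upper end of these three numbers, but only its gap to compound 2 exceeds the scatter. The two relevant steps are a 2.7-fold higher number from compound 2 to compound 3 (0.43 log units; beyond the scatter) and a 2.0-fold higher number from compound 1 to compound 3 (0.30 log units; within the scatter).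

The next change is thiophen-2-yl in place of pyridin-3-yl on a saturated chain carbon bound to an oxygen on an aromatic ring. Among the compounds with values here, the closest precedent is the exchange at this same place, a 2.7-fold higher number from compound 2 to compound 3 (0.43 log units; beyond the scatter), which is modest. The larger change from the quinolinyl ethyl arm to the benzothiazolyl methoxy arm gave only a 1.3-fold lower number from compound 1 to compound 2 (0.12 log units; within the scatter). So far, then, the series has tolerated quite different groups here, though three compounds make a thin basis and none carries a thiophene.

A small move towards a lower number is expected, probably not beyond the scatter. The estimated step is a 1.6-fold lower number from compound 3 to compound 4 (0.20 log units; within the scatter). The expected value for compound 4 is 5 nM, with an estimated range of 2 nM to 12 nM.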

Compound 4, half-maximal inhibitory concentration: 4 nM
Beside the measured number, compound 4's estimate is 1.3-fold (0.10 log units) above it; the measured number falls inside the stated range.
By their numbers in this assay, from the lowest: compounds 2, 1, 4 and 3 (each within the scatter of the next, the first and the last beyond it).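

In this assay the thiophene arm gives a 2.0-fold lower number from compound 3 to compound 4 (0.30 log units; within the scatter) and also a 1.3-fold higher number from compound 2 to compound 4 (0.12 log units; within the scatter) so compound 4 lies within the scatter of both compounds whose gap, at this place on a saturated chain carbon bound to an oxygen on an aromatic ring, was the only one in the series beyond the scatter. Compound 4 is also the first of the series whose arm carries sulfur as its only ring hetero atom and no ring nitrogen, and replacing the whole arm still shows no change at the digits printed from compound 1 to compound 4 (within the scatter) so a ring nitrogen in the arm is not needed for a number in this range. No measurement among the data accounts for these numbers, and no reason for them can be given.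

On these data alone, it remains open whether a plain phenyl ring, a saturated ring such as cyclohexyl or a basic amine such as piperidin-4-yl would be tolerated on the same chain carbon, or whether thiophen-3-yl would match thiophen-2-yl. As far as these compounds go, a longer chain between the oxygen and the thiophene ring is equally open, as is any substituent on the thiophene ring, such as chloro or methyl.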